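Swapping the Aryl Group on a Cinnamate-Type Ester

The compounds below may be only part of what the source reports. "The series", "measured", "known", "first", "only" and "open" are said of these compounds alone.

In a functional assay on the whole organism (strain Kunming) with Mus musculus as the target, with a stated time of 0.5 h (on this read-out lower numbers stand for an effect already at smaller amounts and higher numbers for an effect only at larger amounts of compound), compound 1 `COc1cc(OC)c(OC)cc1/C=C/COC(=O)/C=C/c1c(OC)ccc(OC)c1OC` gives 476 umol/kg and compound 2 `COc1cc(OC)c(OC)cc1/C=C/COC(=O)/C=C/c1ccc(Br)cc1` gives 446 umol/kg. For the measured compounds named here, these two numbers lie within the usual scatter of each other, so compound 2 stands level with compound 1, the only other measured compound. The next compound to be tested is compound 3 `COc1cccc(/C=C/C(=O)OC/C=C/c2cc(OC)c(OC)cc2OC)c1`. It carries 3-methoxyphenyl in place of 4-bromophenyl on a double-bonded chain carbon bound to a double-bonded chain carbon. Going by the values given here, no measured step shows what such a swap does. Among the compounds with values here, with only two values at hand, both close together, no step beyond the scatter is expected in this assay, and no direction can be favoured. The expected change is small, an estimated 1.0-fold higher number from compound 2 to compound 3 (0.00 log units; within the scatter). For compound 3 the estimated value is 450 umol/kg, with an expected range from 250 umol/kg to 800 umol/kg.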

Compound 3, dose for half-maximal effect: 643 umol/kg
Estimate against measurement, compound 3: 1.4-fold (0.15 log units) below; the range from low to high includes it.
By their numbers in this assay, from the lowest: compounds 2, 1 and 3 (each within the scatter of the next).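

For the compounds shown here, replacing 4-bromophenyl with 3-methoxyphenyl on a double-bonded chain carbon bound to a double-bonded chain carbon gives the first readable step at this position: in this assay it amounts to a 1.4-fold higher number from compound 2 to compound 3 (0.16 log units; within the scatter). The entering group carries a hydrogen-bond acceptor where the leaving group has none, yet this step stays within the scatter, so this pair shows no clear effect of the swap on the dose needed. Nothing measured here offers a reason for the size of this step.

Going by these compounds, what remains open is whether a group of a different kind at this place, such as an amine, a carboxylic acid or a longer chain, would move the number beyond the scatter. The compounds shown also leave open whether any change to the shared core would do so.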